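Moving the chlorine on the benzyl group of compound 3

A few compounds are considered here, and "the series" means these few. Any claim that something is new, unique, unknown or untested is made for them only; others in the source may bear on it.

Measured compounds:
- compound 1, `CC1=C(C(=O)Nc2ccc([N+](=O)[O-])cc2)C(c2ccc(Br)cc2)N=C(SCc2ccccc2)N1`: 13.4%
- compound 2, `CC1=C(C(=O)Nc2ccc([N+](=O)[O-])cc2)C(c2ccc(Br)cc2)N=C(SCc2ccccc2Cl)N1`: 7.7%
- compound 3, `CC1=C(C(=O)Nc2ccc([N+](=O)[O-])cc2)C(c2ccc(Br)cc2)N=C(SCc2cccc(Cl)c2)N1`: 6.7%

All three compounds share one core and differ only in the benzyl group bound to the sulfur. In a functional assay on the whole organism (artery, strain albino) with Rattus norvegicus as the target, with a stated time of 120 min, at a dose of 10 mg/kg by the oral route (a lower number here means less inhibition, a higher number more inhibition at the dose given (going by the name of the read-out)), compound 3 gives 6.7%. The steps that lead to it, a number 1 percentage points lower from compound 2 to compound 3 (within the scatter) and a number 6.7 percentage points lower from compound 1 to compound 3 (within the scatter), both lie within the scatter, so the three compounds cannot be told apart on these numbers.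

Compound 4, `CC1=C(C(=O)Nc2ccc([N+](=O)[O-])cc2)C(c2ccc(Br)cc2)N=C(SCc2ccc(Cl)cc2)N1`, differs from compound 3 by 4-chlorophenyl in place of 3-chlorophenyl on a saturated chain carbon bound to a sulfur. Going by the values given here, the closest step on record is the one from compound 2 to compound 3, which also moved the chlorine around the ring: a number 1 percentage points lower from compound 2 to compound 3 (within the scatter). The two steps that add a chlorine, a number 5.7 percentage points lower from compound 1 to compound 2 (within the scatter) and a number 6.7 percentage points lower from compound 1 to compound 3 (within the scatter), are also within the scatter. Among the compounds with values here, nothing measured so far suggests that the position of the chlorine on the benzyl ring changes the inhibition in this assay.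

Compound 4 is therefore expected to stay close to its neighbours, with an estimated step of a number 1.3 percentage points higher from compound 3 to compound 4 (within the scatter). The estimate for compound 4 in this assay is 8%, expected to fall between 0% and 20%.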

Compound 4, a percentage reported as inhibition, in the whole organism at one dose (the size of the read-out at that dose, not a potency): 13.9%
Estimate against measurement, compound 4: 5.9 percentage points below; measured number inside the range.
By their numbers in this assay, from the lowest: compounds 3, 2, 1 and 4 (each within the scatter of the next).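

With 4-chlorophenyl on the saturated chain carbon bound to the sulfur, all three places for a chlorine on this benzyl ring now have a reading in this assay, and the two steps that complete the set (  a number 7.2 percentage points higher from compound 3 to compound 4 (within the scatter)) and (a number 6.2 percentage points higher from compound 2 to compound 4 (within the scatter)) both stay within the usual scatter, so moving the chlorine around the ring has no visible effect on this read-out. Adding the chlorine at this third place is also within the scatter (a number 0.5 percentage points higher from compound 1 to compound 4 (within the scatter)), which extends to all three chloro compounds what the earlier steps showed for only two: none can be told apart from the unsubstituted benzyl compound 1. No measurement is available here that would explain why these four compounds read alike.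

As far as these compounds go, the ring in these compounds carries only hydrogen or chlorine, so it remains open whether another group there, such as methoxy or a carboxylic acid, or a phenethyl group in place of the benzyl group on the sulfur, would give a step beyond the scatter. Each number also comes from one dose at one time, so it gives the size of the read-out at that dose and leaves the potency of these compounds open.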